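Methoxy for trifluoromethyl on the aryl of compound 3

A few compounds are considered here, and "the series" means these few. Any claim that something is new, unique, unknown or untested is made for them only; others in the source may bear on it.

Compounds measured:
compound 1 `COc1ccc(-c2nc(C(=O)/C=C\Nc3ccc(Cl)cc3)c3ccccn23)cc1`, 37300 nM
compound 2 `COc1ccc(N/C=C\C(=O)c2nc(-c3ccc(OC)cc3)n3ccccc23)cc1`, 15400 nM
compound 3 `O=C(/C=C\Nc1ccc(F)cc1)c1nc(-c2ccc(C(F)(F)F)cc2)n2ccccc12`, > 30000 nM

In a functional assay on BT-474 cells (Homo sapiens) for cytotoxicity, read by MTT assay, with a stated time of 48 h (a lower number here means a stronger inhibitor, a higher number a weaker inhibitor), compound 3 gives only a limit, (the limit of > 30000 nM in this assay, at which 1 of the 3 values shown sits). Compound 4 `COc1ccc(-c2nc(C(=O)/C=C\Nc3ccc(F)cc3)c3ccccn23)cc1` differs from compound 3 in one place: methoxy in place of trifluoromethyl on an aromatic carbon. Within the data shown here, the one measured step, a 2.4-fold lower number from compound 1 to compound 2 (0.38 log units; beyond the scatter), concerns a methoxy on the aniline ring, not the ring changed here, so it bears only loosely on this step. Compound 4 carries the same aryl methoxy as compound 1, whose value is a number, so a number is expected for compound 4 rather than a limit. Compound 4 is estimated at 30000 nM, within 10000 nM to 90000 nM, and the step of a number no higher from compound 3 to compound 4 (the limit leaves the size open) is expected to show stronger inhibition.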

Compound 4, half-maximal inhibitory concentration: > 30000 nM
Compound 4: no number, only a limit; the forecaster's own chance of this, stated with the estimate: 40%; the middle value sits exactly at the limit.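

In this assay, compound 4 gives only a limit, so methoxy in place of trifluoromethyl on this aryl ring yields no readable value: the limit of > 30000 nM in this assay, at which 2 of the 4 values shown sit. The steps to compound 4 from compound 3 and from compound 1 cannot be read. On the aniline ring, fluoro in place of methoxy gives an at least 1.9-fold higher number from compound 2 to compound 4 (0.28 log units; that floor lies within the scatter), so even this step shows no firm loss.

As far as these compounds go, how far compound 3 and compound 4 lie beyond the limit stays open. So does whether an amine or a carboxylic acid at this aryl position would give a readable value.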